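Adding chloro to compound 2

The source may report more compounds than this note shows. Statements on the series, on what has been measured and on what is new or still open speak of the compounds shown alone.

- Compound 1 `COc1ccccc1NC(=O)SC[C@H](NC(C)=O)C(=O)O` gives > 200000 nM (a limit)
- Compound 2 `CC(=O)N[C@@H](CSC(=O)Nc1ccccc1)C(=O)O` gives 153000 nM
- Compound 3 `CSc1ccccc1NC(=O)SC[C@H](NC(C)=O)C(=O)O` gives > 200000 nM (a limit)

These results come from a functional assay on OVCAR-3 cells (Homo sapiens) for cytotoxicity, read by MTT assay, with a stated time of 6 days; a lower number here means a stronger inhibitor, a higher number a weaker inhibitor. Among the compounds with values here, compound 2 holds the only true number here, and the other two entries reflect (the limit of > 200000 nM in this assay, at which 2 of the 3 values shown sit). Compound 4 `CC(=O)N[C@@H](CSC(=O)Nc1ccc(Cl)cc1)C(=O)O` differs from compound 2 by chloro in place of hydrogen on an aromatic carbon, which is chloro in place of hydrogen on an aromatic carbon. Within the data shown here, two measured steps bear on this change, though neither introduces chloro. They are an at least 1.3-fold lower number from compound 1 to compound 2 (0.11 log units; that floor lies within the scatter) and an at least 1.3-fold higher number from compound 2 to compound 3 (0.11 log units; that floor lies within the scatter), and each is only a floor within the scatter. No step beyond the scatter is therefore expected in this assay, and no direction is favoured. The expected step is a 1.3-fold lower number from compound 2 to compound 4 (0.11 log units; within the scatter). For compound 4 the estimated value is 120000 nM, with an expected range from 50000 nM to 250000 nM.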

Compound 4, half-maximal inhibitory concentration: > 200000 nM
Compound 4 gave a limit, no number; the forecaster's own chance of this, stated with the estimate: 25%; at least 1.6-fold (0.22 log units) between middle value and limit.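

Chloro in place of hydrogen, on the aromatic carbon para to a large group, adds a second kind of substituent and a new position to the methoxy and methylsulfanyl compounds, and in this assay it gives an at least 1.3-fold higher number from compound 2 to compound 4 (0.11 log units; that floor lies within the scatter). Compound 4 gives only a limit, so this step has a floor and no true size. Compound 2 remains the only compound with a true number: the limit of > 200000 nM in this assay, at which 3 of the 4 values shown sit.

Going by these compounds, how far compound 4 truly lies from compound 2 stays open. On these data alone, whether an amine or a longer chain at this position would give a readable number also stays open.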